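A few compounds are considered here, and "the series" means these few. Any claim that something is new, unique, unknown or untested is made for them only; others in the source may bear on it.

For the measured compounds named here, in a functional assay on MCF7 cells (Homo sapiens) for antiproliferative activity, read by MTT assay, with a stated time of 48 h (on this read-out higher numbers stand for weaker inhibition and lower numbers for stronger inhibition), three compounds with an amide side chain have numbers so far. Compound 2 (`C=C(c1ccc2c(c1)C=CC(C)(C)O2)c1ccc(OC)cc1NC(=O)CO`) gives 390 nM, the middle of the three. Compound 3 (`C=C(c1cc(OC)c(OC)c(OC)c1)c1ccc(OC)cc1NC(=O)CO`) lies lower at 110 nM, and compound 1 (`CNCC(=O)Nc1cc(OC)ccc1C(=O)c1ccc(OC)c2c1C=CC(C)(C)O2`) lies higher at 3040 nM. Both gaps to compound 2 are beyond the usual scatter.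

Compound 4 (`C=C(c1ccc2c(c1)C=CC(C)(C)O2)c1ccc(OC)cc1NC(=O)CNC`) has not yet been measured. It departs from compound 2 in one place: methylamino in place of hydroxy on a saturated chain carbon bound to a carbonyl carbon, with methylamino in place of hydroxy on a saturated chain carbon bound to a carbonyl carbon. Going by the values given here, no measured pair isolates this change. Compound 1 also carries methylamino and gives the highest number, 3040 nM, but its core differs from that of compound 2, so it offers only a weak hint of direction. In this assay, a small move towards weaker inhibition is therefore expected, with the estimated step, a 1.8-fold higher number from compound 2 to compound 4 (0.25 log units; within the scatter), staying close to the scatter. For compound 4 the estimated value is 700 nM, with an expected range of 220 nM to 2200 nM.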

Compound 4, half-maximal inhibitory concentration: 720 nM
Estimate against measurement, compound 4: 1.0-fold (0.01 log units) below; the range from low to high includes it.
By their numbers in this assay, from the lowest: compound 3; then compounds 2 and 4 (each within the scatter of the next); then compound 1.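

In this assay, for the compounds shown here, the pair of compound 2 and compound 4 is the first to isolate methylamino in place of hydroxy on a saturated chain carbon bound to a carbonyl carbon. The step is a 1.8-fold higher number from compound 2 to compound 4 (0.27 log units; within the scatter) and so shows that, on this shared core, the exchange at this position cannot be told apart from the scatter. No measurement at hand offers an explanation for this result.

Whether the exchange behaves the same way on the core of compound 3, where only hydroxy is shown, remains open. The compounds shown also do not tell how a dimethylamino group, a primary amine, a carboxylic acid or a longer chain would fare on this carbon.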